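Cytotoxicity of a sulfonylphenyl replacement on the shared core

This account rests on a few compounds, and the source may have more. Where it says the series, first, only, none or still open, it means among the compounds named here.

Compound 3 `COc1ccc(-n2c(=O)n(Cc3cc4cc(Cl)ccc4n3CCCC#N)c3cnccc32)c(C)c1` was tested in an ADME assay on HeLa cells (Homo sapiens) for cytotoxicity, read by ATP content, with a stated time of 3 days; on this read-out lower numbers stand for higher toxicity in this test and higher numbers for lower toxicity in this test. In this test compound 3 shows only a limit of the assay, > 50000 nM. Compound 1 `COc1ccc(-n2c(=O)n(Cc3cc4cc(Cl)ccc4n3CCCC#N)c3cnccc32)cc1OC` likewise gives only a limit in this assay, > 50000 nM. Compound 2 `Cn1ccc(-n2c(=O)n(Cc3cc4cc(Cl)ccc4n3CCCC#N)c3cnccc32)n1` also returns a limit in this assay, > 50000 nM. All three measured values therefore sit at the same edge of the measurement, (the limit of > 50000 nM in this assay, at which 3 of the 3 values shown sit), so the step that the two limits leave unreadable from compound 1 to compound 3 and the step that the two limits leave unreadable from compound 2 to compound 3, like a step that the two limits leave unreadable from compound 1 to compound 2, cannot be read in size or direction.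

Compound 4 `CS(=O)(=O)c1ccc(-n2c(=O)n(Cc3cc4cc(Cl)ccc4n3CCCC#N)c3cnccc32)cc1` differs from compound 3 by 4-(methylsulfonyl)phenyl in place of 4-methoxy-2-methylphenyl on an aromatic nitrogen. The measured steps that bear on this position are all unreadable, so nothing seen so far points to a move in either direction beyond the scatter, and the one thing the record does show is that three different groups on this aromatic nitrogen all leave the value at the limit. Compound 4 is therefore expected to remain at or near that same limit in this assay, with the step that the limit leaves unreadable from compound 3 to compound 4 estimated as no more than the scatter. The estimate for compound 4 is 60000 nM, ranging from 20000 nM to 200000 nM.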

Compound 4, half-maximal cytotoxic concentration: > 50000 nM
Compound 4 ended at the assay's limit; the forecaster's own chance of this, stated with the estimate: 85%; the middle value is on the limit's open side.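

In this assay compound 4 gives only a limit of the assay, > 50000 nM. Its steps from compound 1, compound 2 and compound 3 cannot be read in size or direction, and all four compounds sit at one edge of the measurement: the limit of > 50000 nM in this assay, at which 4 of the 4 values shown sit. The compounds shown leave open whether any group on this aromatic nitrogen would bring the value off that limit.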